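Octanesulfonamide benzoic acids: ketone-linked aryl variant

The compounds below may be only part of what the source reports. "The series", "measured", "known", "first", "only" and "open" are said of these compounds alone.

Measured so far in an assay on mitochondria (strain BALB/c) for inhibition of glycerol-3-phosphate acyltransferase 1, mitochondrial (Mus musculus), read by scintillation counting, with a stated time of 10 min; on this read-out lower numbers stand for stronger inhibition and higher numbers for weaker inhibition:
compound 1, `CCCCCCCCS(=O)(=O)Nc1cc(-c2ccc(-c3ccccc3)cc2)ccc1C(=O)O`, 13500 nM
compound 2, `CCCCCCCCS(=O)(=O)Nc1ccc(-c2cccc(Cl)c2)cc1C(=O)O`, 8900 nM
compound 3, `CCCCCCCCS(=O)(=O)Nc1ccc(C(=O)c2ccc(-c3ccccc3)cc2)cc1C(=O)O`, 13000 nM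

Compound 2 gives the lowest number of the three, yet its gaps to compound 1 and to compound 3 both lie within the usual scatter, so the three stand as one group with no order among them.

Compound 4, `CCCCCCCCS(=O)(=O)Nc1ccc(C(=O)c2ccccc2OC)cc1C(=O)O`, is not yet measured in this assay. Its difference from compound 2 is (2-methoxyphenyl)carbonyl in place of 3-chlorophenyl on an aromatic carbon. Compound 3 already carries a carbonyl-linked aryl on the shared core and gives 13000 nM, within the scatter of compound 2, so for compound 4 no step beyond the scatter is expected in either direction; the expected step is a 1.3-fold higher number from compound 2 to compound 4 (0.13 log units; within the scatter). Compound 4 is therefore estimated at 12000 nM, with a range from 5000 nM to 30000 nM.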

Compound 4, half-maximal inhibitory concentration: 59200 nM
Compound 4: the middle estimate sits 4.9-fold (0.69 log units) below what was measured; measured number outside the range, above it.
By their numbers in this assay, from the lowest: compounds 2, 3 and 1 (each within the scatter of the next); then compound 4.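

In this assay, among these compounds, (2-methoxyphenyl)carbonyl in place of 3-chlorophenyl gives a 6.7-fold higher number from compound 2 to compound 4 (0.82 log units; beyond the scatter) and is the first step beyond the scatter. This position, meta to a carboxy group and para to a large group, therefore responds to the group it carries, which compounds 1, 2 and 3, all within the scatter of one another, did not show. No measured evidence here bears on the reason for this step.

The change brings in the carbonyl and the methoxy together, so the compounds shown do not separate their contributions. As far as these compounds go, how an amine in place of the methoxy would read out also remains open.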